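Permeability notes: aryl ether to naphthyl on the shared core

This account rests on a few compounds, and the source may have more. Where it says the series, first, only, none or still open, it means among the compounds named here.

Compound 3 `COc1ccc(F)cc1CNCCCNc1ccnc2cc(Oc3ccc(C(C)(C)C)cc3)ccc12` gives 317 10^-6 cm/s in an ADME assay for permeability, using PAMPA, with a stated time of 30 min, at pH 7.4; on this read-out lower numbers stand for lower permeability and higher numbers for higher permeability; compound 1 `COc1ccc(Oc2ccc3c(NCCCNCc4cc(F)ccc4OC)ccnc3c2)cc1` gives 317 10^-6 cm/s, and the two sit level, no change at the digits printed from compound 1 to compound 3 (within the scatter), at the top of the three, while compound 2 `COc1ccc(F)cc1CNCCCNc1ccnc2cc(C3CCCCC3)ccc12` gives 23 10^-6 cm/s. Compound 4 `COc1ccc(F)cc1CNCCCNc1ccnc2cc(-c3cccc4ccccc34)ccc12` differs from compound 3 by naphthalen-1-yl in place of 4-(tert-butyl)phenoxy on an aromatic carbon. Among the measured compounds shown here, the steps that bear on this are a 14-fold higher number from compound 2 to compound 3 (1.14 log units; beyond the scatter) and a 14-fold lower number from compound 1 to compound 2 (1.14 log units; beyond the scatter), each large, where a directly attached ring replaced an aryloxy group or the reverse. Since the change to compound 4 again removes an aryloxy group for a directly attached ring, this assay is expected to fall by a 3.5-fold lower number from compound 3 to compound 4 (0.55 log units; beyond the scatter). Compound 4 is therefore estimated at 90 10^-6 cm/s, with a range from 25 10^-6 cm/s to 320 10^-6 cm/s.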

Compound 4, apparent permeability: 237 10^-6 cm/s
Compound 4: middle estimate off by 2.6-fold (0.42 log units), on the low side; the measured number falls inside the stated range.
By their numbers in this assay, from the lowest: compound 2; then compounds 4, 1 and 3 (each within the scatter of the next).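

At this aromatic carbon, the aryloxy link is not required for a high number in this assay: naphthalen-1-yl sits level with both aryloxy groups, with a 1.3-fold lower number from compound 3 to compound 4 (0.13 log units; within the scatter) and a 1.3-fold lower number from compound 1 to compound 4 (0.13 log units; within the scatter). Only cyclohexyl stands apart, with a 10-fold higher number from compound 2 to compound 4 (1.01 log units; beyond the scatter), so among these four compounds the split runs between cyclohexyl and the aromatic groups, not between ether and direct attachment. No measurement shown explains this. Open, going by these compounds, is whether naphthalen-2-yl reads the same here, and how a morpholine or a carboxylic acid at this carbon would read.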